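A few compounds are considered here, and "the series" means these few. Any claim that something is new, unique, unknown or untested is made for them only; others in the source may bear on it.

Among the compounds with values here, compound 1 `NC(=O)c1c(NC(=O)c2ccccc2Cl)sc2c1CCN(Cc1ccc([N+](=O)[O-])cc1)C2` is a weak inhibitor: in a functional assay on HL-60 cells (Homo sapiens) for antiproliferative activity, with a stated time of 24 h (a lower number here means a stronger inhibitor, a higher number a weaker inhibitor), compound 1 gives 11400 nM, the only measured number here. Compound 2 `NC(=O)c1c(NC(=O)c2ccc(C(F)(F)F)cc2)sc2c1CCN(Cc1ccccc1F)C2` reaches only a limit of the assay, > 50000 nM in this assay, as the limit of > 50000 nM in this assay, at which 1 of the 2 values shown sits, records. Compound 3 `COc1ccc(NC(=S)N2CCc3c(sc(NC(=O)c4ccccc4Cl)c3C(N)=O)C2)cc1` is not yet measured; it differs from compound 1 in one place: a group of 11 heavy atoms (8 carbon, 1 nitrogen, 1 oxygen, 1 sulfur; one six-membered aromatic ring of carbon only) in place of a group of 10 heavy atoms (7 carbon, 1 nitrogen, 2 oxygen; one six-membered aromatic ring of carbon only), on an amine nitrogen in a ring. Within the data shown here, with no measured step to lean on, the expected change a 1.1-fold higher number from compound 1 to compound 3 (0.06 log units; within the scatter) is small, within the scatter or at most slightly toward weaker. Compound 3 is therefore estimated at 13000 nM, with a range from 3500 nM to 50000 nM in this assay.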

Compound 3, half-maximal inhibitory concentration: 15700 nM
Compound 3: the middle estimate sits 1.2-fold (0.08 log units) below what was measured; the range from low to high includes it.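

In this assay, replacing the 4-nitrobenzyl group on the amine nitrogen in a ring with the group that holds sulfur and a hydrogen-bond donor gives a 1.4-fold higher number from compound 1 to compound 3 (0.14 log units; within the scatter). This position therefore takes two quite different groups without a readable change in the number, and the inhibitor remains weak. Nothing shown gives a reason for this result. On these data alone, whether a simple amine, a carboxylic acid or a longer chain on this nitrogen would move the number beyond the scatter stays open. So does whether any group here could give a strong inhibitor.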